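The source may hold more compounds than are shown below. What is called first, only, known or untested is meant among the compounds shown, and "the series" means these compounds.

Compound 2 `COc1ccccc1-c1cn(C[C@H](O)[C@H]2OC(=O)C(OCc3ccccc3)=C2OCc2ccccc2)nn1` stands only at a limit in a functional assay on CFPAC-1 cells (Homo sapiens) for antiproliferative activity, read by MTT assay, with a stated time of 72 h (a lower number here means a stronger inhibitor, a higher number a weaker inhibitor), where compound 2 gives > 100000 nM, a limit rather than a number. Compound 1 `Cc1ccc(-c2cn(C/C=C3\OC(=O)C(OCc4ccccc4)=C3OCc3ccccc3)nn2)cc1` gives > 100000 nM, also a limit. Compound 3 `COc1ccccc1-c1cn(C/C=C2\OC(=O)C(OCc3ccccc3)=C2OCc2ccccc2)nn1` gives > 100000 nM, again a limit. All three sit at the limit of > 100000 nM in this assay, at which 3 of the 3 values shown sit. For the measured compounds named here, the one measured change of the aryl group, a step that the two limits leave unreadable from compound 1 to compound 3, therefore has no readable size. Compound 4 `Cc1ccc(-c2cn(C[C@H](O)[C@H]3OC(=O)C(OCc4ccccc4)=C3OCc3ccccc3)nn2)cc1` differs from compound 2 by 4-methylphenyl in place of 2-methoxyphenyl on an aromatic carbon. Because a step that the two limits leave unreadable from compound 1 to compound 3 could not be sized, the same swap on the saturated core gives no reason to expect a readable gain. Compound 4 is expected to give 200000 nM, with a range from 100000 nM to 1000000 nM. The expected step is a step that the limit leaves unreadable from compound 2 to compound 4.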

Compound 4, half-maximal inhibitory concentration: > 100000 nM
Compound 4 was reported as a limit; the forecaster's own chance of this, stated with the estimate: 90%; the middle value does not contradict the limit.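

Compound 2 and compound 4 both stand only at a limit, so swapping 2-methoxyphenyl for 4-methylphenyl gives no readable step: the limit of > 100000 nM in this assay, at which 4 of the 4 values shown sit.

The compounds shown leave open whether any change to them would give a readable value.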